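The compounds below may be only part of what the source reports. "The series", "measured", "known", "first", "only" and "open" are said of these compounds alone.

Measured compounds in a physicochemical assay for lipophilicity; a lower number here means a more polar compound, a higher number a more lipophilic compound:
compound 1, `COc1ccc(-c2[nH]c3ccccc3c2C2=C(Br)C(=O)NC2=O)cc1`, 2.42
compound 2, `COc1ccc2[nH]c(-c3ccccc3)c(C3=C(Br)C(=O)NC3=O)c2c1`, 2.48
compound 3, `COc1cccc(-c2[nH]c3ccc(OC)cc3c2C2=C(Br)C(=O)NC2=O)c1`, 2.79

Compound 3 stands highest of the three in this assay; its nearest neighbour is compound 2 and its furthest is compound 1, both beyond the scatter. Going by the values given here, the one step that can be traced between measured compounds is a number 0.31 log units higher from compound 2 to compound 3 (beyond the scatter), which shows that a methoxy entering on an aromatic carbon of the shared core moved the number up by a modest amount.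

Compound 4, `CCCCCCc1ccc2[nH]c(-c3cccc(OC)c3)c(C3=C(Br)C(=O)NC3=O)c2c1`, has not yet been measured in this assay. It differs from compound 3 in one place: hexyl in place of methoxy on an aromatic carbon. Among the compounds with values here, the measured step from compound 2 to compound 3 bears on the part that leaves, since it shows what a methoxy on that core is worth; no measured pair here shows what a hexyl on that core is worth, so that part of the expectation rests on the six carbons entering and the one acceptor leaving. On that basis compound 4 is expected to give a considerably higher number, with the step from compound 3 estimated at a number 2.51 log units higher from compound 3 to compound 4 (beyond the scatter). For compound 4 the expected value in this assay is 5.3, with a range from 4.5 to 6.1.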

Compound 4, partition coefficient: 4.26
Compound 4: middle estimate off by 1.04 log units, on the high side, and the stated range ends above it.
By their numbers in this assay, from the lowest: compounds 1 and 2 (each within the scatter of the next); then compound 3; then compound 4.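

At this position on the shared core, on the six-membered aromatic ring and para to a fused ring, exchanging methoxy for hexyl gives a number 1.47 log units higher from compound 3 to compound 4 (beyond the scatter) in this assay and so makes compound 4 the highest of the four compounds. Going by these compounds alone, the earlier compounds offered only a modest step on another aromatic carbon, a number 0.31 log units higher from compound 2 to compound 3 (beyond the scatter), so this is the first sign that a change at this position can move the number by a large amount. Nothing shown explains the size of this step, and this single exchange cannot separate what the six carbons entering contribute from what the acceptor leaving contributes.

The compounds shown leave open how the number follows chain length at this position, since neither a propyl nor an octyl chain stands there, and whether it climbs evenly from methoxy to hexyl cannot be read from one pair. They also leave open how far the number would fall with an amine or a carboxylic acid at this position, and where a plain hydrogen there would sit with the other ring's methoxy kept in place.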